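The compounds below may be only part of what the source reports. "The series", "measured", "known", "first", "only" and "open" are said of these compounds alone.

Measured compounds:
compound 1 `NS(=O)(=O)c1ccc(Nc2nc(N/N=C/c3ccc(C(F)(F)F)cc3)nc(Nc3ccccc3)n2)cc1`: 1950 nM
compound 2 `Cc1nn(-c2ccccc2)cc1/C=N/Nc1nc(Nc2ccccc2)nc(Nc2ccc(S(N)(=O)=O)cc2)n1`: 1740 nM

Both numbers come from a functional assay on NCI-H23 cells (Homo sapiens) for inhibition, read by sulforhodamine B assay, with a stated time of 48 h; on this read-out higher numbers stand for weaker inhibition of growth and lower numbers for stronger inhibition of growth. On the two values shown, compound 2 carries the lowest number, but its separation from compound 1 is a 1.1-fold lower number from compound 1 to compound 2 (0.05 log units; within the scatter), so the two cannot be told apart. The next compound, compound 3 `NS(=O)(=O)c1ccc(Nc2nc(N/N=C/c3ccccn3)nc(Nc3ccccc3)n2)cc1`, differs from compound 2 by pyridin-2-yl in place of 3-methyl-1-phenyl-1H-pyrazol-4-yl on a carbon with a double bond to nitrogen. Among the compounds with values here, the only measured step that touches this position is a 1.1-fold lower number from compound 1 to compound 2 (0.05 log units; within the scatter), where one aromatic group replaced another at the same carbon and the number barely moved. That single step gives no sign that swapping the aromatic group at this carbon matters within this assay, so for compound 3 no step beyond the scatter is expected in either direction, and a 1.1-fold higher number from compound 2 to compound 3 (0.06 log units; within the scatter) is the expected change. Compound 3 is estimated at 2000 nM, with a likely range from 700 nM to 6000 nM.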

Compound 3, concentration for 50% growth inhibition: 1210 nM
Compound 3: the middle estimate sits 1.7-fold (0.22 log units) above what was measured; the range from low to high includes it.
By their numbers in this assay, from the lowest: compounds 3, 2 and 1 (each within the scatter of the next).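

In this assay, the carbon with a double bond to nitrogen accepts a smaller aromatic group without a step beyond the scatter: pyridin-2-yl, with 6 heavy atoms, replaces 3-methyl-1-phenyl-1H-pyrazol-4-yl in a 1.4-fold lower number from compound 2 to compound 3 (0.16 log units; within the scatter). Putting the same pyridin-2-yl in place of 4-(trifluoromethyl)phenyl gives a 1.6-fold lower number from compound 1 to compound 3 (0.21 log units; within the scatter), so across these three compounds, a ring nitrogen and a change in group size both come with numbers that cannot be told apart. No measurement is available that would explain this result.

Going by these compounds, all three groups at this carbon are aromatic rings, so it stays open whether a cyclohexyl ring, a longer alkyl chain, or a group carrying an amine or a carboxylic acid would shift the number in this assay. On these data alone, the effect of changing the rest of the molecule, which is the same in all three compounds, also stays open.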